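Furan isomer swap in the acrylamide pair

The source may hold more compounds than are shown below. What is called first, only, known or untested is meant among the compounds shown, and "the series" means these compounds.

Two compounds give numbers in a functional assay on SJ-G2 cells (Homo sapiens) for inhibition, read by MTT assay, with a stated time of 72 h; on this read-out higher numbers stand for weaker inhibition of growth and lower numbers for stronger inhibition of growth. Compound 1 `N#C/C(=C\c1c(F)c(F)c(F)c(F)c1F)C(=O)c1c[nH]c2ccccc12` gives 14000 nM in this assay. Compound 2 `COc1ccc(CNC(=O)/C(C#N)=C/c2ccco2)cc1` gives 31000 nM in this assay, the highest of the two numbers; compound 1 is its nearest neighbour with a lower number, a gap that lies beyond the usual scatter. Within the data shown here, the two share no single point of difference, so no step between them is counted.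

Compound 3 `COc1ccc(CNC(=O)/C(C#N)=C/c2ccoc2)cc1` has not been measured in this assay. It differs from compound 2 by furan-3-yl in place of furan-2-yl on a double-bonded chain carbon bound to a double-bonded chain carbon; the atoms are the same, joined differently. Among the measured compounds shown here, no measured pair shows what this change does. The expected step from compound 2 to compound 3, a 1.0-fold lower number from compound 2 to compound 3 (0.01 log units; within the scatter), is small, with no direction beyond the scatter. Compound 3 is therefore estimated at 30000 nM in this assay, within a range from 12000 nM to 80000 nM.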

Compound 3, concentration for 50% growth inhibition: 8000 nM
Estimate against measurement, compound 3: 3.8-fold (0.57 log units) above; measured number outside the range, below it.
By their numbers in this assay, from the lowest: compounds 3 and 1 (each within the scatter of the next); then compound 2.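

In this assay, the way the furan is joined on a double-bonded chain carbon bound to a double-bonded chain carbon matters: furan-3-yl in place of furan-2-yl gives a 3.9-fold lower number from compound 2 to compound 3 (0.59 log units; beyond the scatter), a step beyond the scatter. The swap leaves the atoms and the counted donors and acceptors unchanged, so a difference in ring attachment alone is enough to shift growth inhibition in this pair. No measured property accompanies the step, and what lies behind it remains unexplained.

From the compounds shown here alone, this reading rests on one pair, so it remains open whether the same swap gives a similar step when the rest of the molecule differs. Also open, going by these compounds, is how a methyl group or a carboxylic acid carried on the furan-3-yl ring would affect growth inhibition.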